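A few compounds are considered here, and "the series" means these few. Any claim that something is new, unique, unknown or untested is made for them only; others in the source may bear on it.

Working notes, series measured in a functional assay on QGY-7703 cells (Homo sapiens) for cytotoxicity, read by MTT assay, with a stated time of 24 h; a higher number here means a weaker inhibitor, a lower number a stronger inhibitor:

- Compound 1 `COc1cc(/C=C2\CN(S(=O)(=O)c3ccc(F)cc3)C/C(=C\c3ccccc3F)C2=O)cc(OC)c1OC`: 13300 nM
- Compound 2 `COc1cc(/C=C2\CN(S(=O)(=O)c3ccc(F)cc3)C/C(=C\c3ccc(C#N)cc3)C2=O)cc(OC)c1OC`: 4980 nM
- Compound 3 `COc1cc(/C=C2\CN(S(=O)(=O)c3ccc(F)cc3)C/C(=C\c3cc(OC)c(OC)c(OC)c3)C2=O)cc(OC)c1`: 5200 nM

Compound 2 cannot be separated from compound 3 on these numbers, a 1.0-fold higher number from compound 2 to compound 3 (0.02 log units; within the scatter). Together they stand clear of compound 1, with a 2.7-fold lower number from compound 1 to compound 2 (0.43 log units; beyond the scatter) and a 2.6-fold lower number from compound 1 to compound 3 (0.41 log units; beyond the scatter).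

The next comparison is compound 4 `COc1cc(/C=C2\CN(S(=O)(=O)c3ccc(NC(C)=O)cc3)C/C(=C\c3ccc(C#N)cc3)C2=O)cc(OC)c1OC`, which keeps everything in compound 2 except one group: acetamido in place of fluoro on an aromatic carbon. The new acetamido sits on an aromatic carbon, para to a large group.

Going by the values given here, no measured step touches this position. All three steps change only the aryl group on the double-bonded chain carbon, so they bear on the question indirectly. Among the compounds with values here, they show only that changes elsewhere on the shared core have moved this assay modestly, as in a 2.7-fold lower number from compound 1 to compound 2 (0.43 log units; beyond the scatter), or not at all.

With no direct evidence on direction, no step beyond the scatter is expected, and the expected step is a 1.2-fold higher number from compound 2 to compound 4 (0.08 log units; within the scatter). The estimate for compound 4 is 6000 nM, with an expected range from 2200 nM to 16000 nM.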

Compound 4, half-maximal inhibitory concentration: 1890 nM
Estimate against measurement, compound 4: 3.2-fold (0.50 log units) above; measured number below the stated range.
By their numbers in this assay, from the lowest: compound 4; then compounds 2 and 3 (each within the scatter of the next); then compound 1.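

This position, an aromatic carbon para to a large group, is able to move the number in this assay: 4-acetamidophenyl in place of 4-fluorophenyl gives a 2.6-fold lower number from compound 2 to compound 4 (0.42 log units; beyond the scatter). Going by these compounds alone, the earlier steps changed only the aryl group on the double-bonded chain carbon, so this is the first sign that the other end of the shared core also affects the read-out, and that acetamido is accommodated there without loss. The change enlarges the group and adds a hydrogen-bond donor and acceptor, but nothing available shows which of these, if any, matters.

One pair leaves open whether the step carries over to the 2-fluorophenyl of compound 1 or the 3,5-dimethoxyphenyl of compound 3. On these data alone, how a free amine or a longer acyl chain would read at this position also remains open.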